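Swapping the Aryl Group on the Amine Nitrogen

The source may hold more compounds than are shown below. What is called first, only, known or untested is meant among the compounds shown, and "the series" means these compounds.

Three compounds built on a shared core have been measured in a functional assay, with a stated time of 6 min; on this read-out lower numbers stand for stronger inhibition and higher numbers for weaker inhibition:
Compound 1, `COc1ccc(NCn2nc(-c3ccc4c(c3)OCCO4)oc2=S)cc1`, gives 5830 nM.
Compound 2, `S=c1oc(-c2ccc3c(c2)OCCO3)nn1CNC1CCCCC1`, gives 18400 nM.
Compound 3, `S=c1oc(-c2ccc3c(c2)OCCO3)nn1CNc1cccc(Cl)c1`, gives 6220 nM.

Compound 1 has the lowest number of the three, but compound 3 sits within the scatter of it, with a 1.1-fold higher number from compound 1 to compound 3 (0.03 log units; within the scatter), so the two cannot be ordered. Compound 2 stands apart: a 3.2-fold higher number from compound 1 to compound 2 (0.50 log units; beyond the scatter), and a 3.0-fold lower number from compound 2 to compound 3 (0.47 log units; beyond the scatter).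

Compound 4, `O=[N+]([O-])c1ccccc1NCn1nc(-c2ccc3c(c2)OCCO3)oc1=S`, has not yet been measured. It differs from compound 1 in one place: 2-nitrophenyl in place of 4-methoxyphenyl on an amine nitrogen. The step that bears on it most directly is the exchange of one substituted phenyl for another on the same nitrogen, from compound 1 to compound 3, which stayed within the scatter. For the measured compounds named here, the only step beyond the scatter, from compound 1 to compound 2, replaced the phenyl with cyclohexyl, which compound 4 does not do. On this basis compound 4 is expected to stay close to compound 1 in this assay, with no step beyond the scatter in either direction, though two such swaps are a thin basis. Compound 4 is therefore estimated at 7000 nM, within 2500 nM to 20000 nM, an expected step of a 1.2-fold higher number from compound 1 to compound 4 (0.08 log units; within the scatter).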

Compound 4, half-maximal inhibitory concentration: 10900 nM
Beside the measured number, compound 4's estimate is 1.6-fold (0.19 log units) below it; the measured number falls inside the stated range.
By their numbers in this assay, from the lowest: compounds 1, 3, 4 and 2 (each within the scatter of the next, the first and the last beyond it).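

In this assay, the 2-nitrophenyl group of compound 4 is not separated beyond the scatter from any of the other three groups on the amine nitrogen (a 1.9-fold higher number from compound 1 to compound 4 (0.27 log units; within the scatter)) (a 1.8-fold higher number from compound 3 to compound 4 (0.24 log units; within the scatter)) (a 1.7-fold lower number from compound 2 to compound 4 (0.23 log units; within the scatter)). The earlier compounds shown here suggested a plain split at this position, with the two substituted phenyl groups on one side and cyclohexyl on the other, but compound 4 goes against that split: it carries a substituted phenyl yet lies within the scatter of compound 2 as well as of compound 1 and compound 3, so the presence of a phenyl ring alone does not set a compound apart from the cyclohexyl compound here, although compound 1 and compound 3 remain apart from it. Nothing measured here accounts for these steps, so the result stands as an observation only.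

The compounds shown leave open how an unsubstituted phenyl, a benzyl group or a pyridine ring on this nitrogen would compare in this assay. They also leave open whether a group bearing an amine or a carboxylic acid could move the number beyond the scatter from compound 1 in either direction.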